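The source may hold more compounds than are shown below. What is called first, only, known or untested is meant among the compounds shown, and "the series" means these compounds.

Compound 1 `Nc1nc(C(F)(F)F)cc2c1[nH]c(=O)n2Cc1ccc(NCCN2CCCCC2)nc1` stands alone in this set with a definite number in an in vitro ADME assay on microsomes from liver (Homo sapiens) for pharmacokinetics; a higher number here means faster removal of the compound, a lower number slower removal: compound 1 gives 13 mL.min-1.g-1. Compound 2 `Nc1nc(C(F)(F)F)cc2c1[nH]c(=O)n2Cc1ccc(NCc2ccccc2)nc1` is the other measured compound. In this assay compound 2 gives only a limit of the assay, < 8 mL.min-1.g-1. Going by the values given here, the single measured step, an at least 1.6-fold lower number from compound 1 to compound 2 (0.21 log units; that floor lies within the scatter), is known only as a floor, and its size stays within the scatter because the limit of < 8 mL.min-1.g-1 in this assay, at which 1 of the 2 values shown sits, caps what compound 2 can contribute.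

Compound 3 `CN1CCN(CCN(C)c2ccc(Cn3c(=O)[nH]c4c(N)nc(C(F)(F)F)cc43)cn2)CC1` has not yet been measured in this assay. Relative to compound 1 it carries methyl(2-(4-methylpiperazin-1-yl)ethyl)amino in place of (2-(piperidin-1-yl)ethyl)amino on an aromatic carbon. Among the compounds with values here, this change alters the same side chain as the measured step, but it exchanges the saturated ring for a different one and methylates the nitrogen on the aromatic ring, a pairing no measured compound covers. Within the data shown here, the only comparison available, from compound 1 to compound 2, did not leave the scatter. One therefore expects no movement beyond the scatter for compound 3, no change at the digits printed from compound 1 to compound 3 (within the scatter). Compound 3 is estimated to give 13 mL.min-1.g-1 in this assay, within a range of 6 mL.min-1.g-1 to 28 mL.min-1.g-1.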

Compound 3, intrinsic clearance in microsomes in the Homo sapiens assay: 25 mL.min-1.g-1
Compound 3: the middle estimate sits 1.9-fold (0.28 log units) below what was measured, and the stated range covers the measured number.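

In the Homo sapiens assay, methyl(2-(4-methylpiperazin-1-yl)ethyl)amino in place of (2-(piperidin-1-yl)ethyl)amino on this aromatic carbon gives a 1.9-fold higher number from compound 1 to compound 3 (0.28 log units; within the scatter). In a physicochemical assay for lipophilicity (on this read-out higher numbers stand for higher lipophilicity and lower numbers for lower lipophilicity), compound 1 gives 1.3 and compound 3 gives 1.5. In the physicochemical assay the same exchange gives a number 0.20 log units higher from compound 1 to compound 3 (within the scatter), so on both read-outs these two side chains cannot be told apart. Set against benzylamino, the same group gives, in the Homo sapiens assay, an at least 3.1-fold higher number from compound 2 to compound 3 (0.49 log units; beyond the scatter), the first step at this position to clear the scatter, which shows that the choice of group here can shift the read-out. Compound 2 is recorded only as a limit of the assay, so this step is known as a floor and its full size stays unknown: the limit of < 8 mL.min-1.g-1 in the Homo sapiens assay, at which 1 of the 3 values shown sits.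

The exchange from compound 1 to compound 3 joins two changes, the added methyl on the nitrogen bound to the aromatic ring and the piperazine ring with its own methyl in place of piperidine, and the compounds shown do not separate them. From the compounds shown here alone, it also remains open whether a morpholine ring at the end of the ethyl chain, or a propyl chain in place of the ethyl chain, would keep the number in the same range.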